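Methyl to Methoxy on the Arylamino Ring of Compound 3

The source may hold more compounds than are shown below. What is called first, only, known or untested is meant among the compounds shown, and "the series" means these compounds.

Measured so far:
Compound 1, `CNC(=O)c1ccccc1Oc1nc(Nc2ccc(C(F)(F)F)cc2)ncc1Br`: in a functional assay on A549 cells (Homo sapiens) for antiproliferative activity, read by MTT assay, with a stated time of 24 h (a higher number here means a weaker inhibitor, a lower number a stronger inhibitor), compound 1 gives > 50000 nM, which is a limit of the assay and not a number.
Compound 2, `CNC(=O)c1ccccc1Oc1nc(Nc2ccccc2F)ncc1Br`: in this assay compound 2 gives 35500 nM.
Compound 3, `CNC(=O)c1ccccc1Oc1nc(Nc2cccc(C)c2)ncc1Br`: in this assay compound 3 gives 6100 nM.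

Compound 3 holds the lowest of the two numbers recorded; its nearest neighbour is reached by a 5.8-fold lower number from compound 2 to compound 3 (0.76 log units; beyond the scatter). Compound 4, `CNC(=O)c1ccccc1Oc1nc(Nc2cccc(OC)c2)ncc1Br`, differs from compound 3 by methoxy in place of methyl on an aromatic carbon. Among the compounds with values here, no measured step exchanges methyl for methoxy; the single measured step, a 5.8-fold lower number from compound 2 to compound 3 (0.76 log units; beyond the scatter), alters both the group and its place on the ring, so it does not bear directly on this change. Compound 4 is therefore expected to lie close to compound 3, with a 1.0-fold lower number from compound 3 to compound 4 (0.01 log units; within the scatter) expected to stay within the scatter. For compound 4 the estimate in this assay is 6000 nM, between 2000 nM and 18000 nM.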

Compound 4, half-maximal inhibitory concentration: 6230 nM
Compound 4: middle estimate off by 1.0-fold (0.02 log units), on the low side; the measured number falls inside the stated range.
By their numbers in this assay, from the lowest: compounds 3 and 4 (each within the scatter of the next); then compound 2. At a limit, above all of these: compound 1.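

In this assay, methoxy in place of methyl on this aromatic carbon gives a 1.0-fold higher number from compound 3 to compound 4 (0.01 log units; within the scatter) and so adds a hydrogen-bond acceptor without moving the number beyond the scatter. Against the 2-fluorophenyl group, the 3-methoxyphenyl group gives a 5.7-fold lower number from compound 2 to compound 4 (0.76 log units; beyond the scatter) and thus repeats what the 3-methylphenyl group showed. Nothing measured here accounts for this sameness. On these data alone, whether the number would hold with an amine, a carboxylic acid or a longer chain on this aromatic carbon remains open.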